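Shifting a Methoxy Group: From Compound 2 to Compound 4

This account rests on a few compounds, and the source may have more. Where it says the series, first, only, none or still open, it means among the compounds named here.

- Compound 1 `COc1ccc(C2=C(c3cc(OC)c(OC)c(OC)c3)C(=O)CC2O[SiH2]C(C)(C)C)cc1`: > 100 ug/mL (a limit of the assay, not a number)
- Compound 2 `COc1ccc(OC)c(C2=C(c3cc(OC)c(OC)c(OC)c3)C(=O)CC2O[SiH2]C(C)(C)C)c1`: 9.5 ug/mL
- Compound 3 `COc1ccc(C2=C(c3cc(OC)c(OC)c(OC)c3)C(=O)C(O)C2)cc1NC(=O)c1ccccc1`: > 100 ug/mL (a limit of the assay, not a number)

All three values come from an ADME assay on HEK293 cells (Homo sapiens) for cytotoxicity, read by MTT assay, with a stated time of 72 h; on this read-out higher numbers stand for weaker inhibition and lower numbers for stronger inhibition. Within the data shown here, compound 2 holds the only exact number among them. The rest of the picture is the limit of > 100 ug/mL in this assay, at which 2 of the 3 values shown sit.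

Compound 4 `COc1ccc(C2=C(c3cc(OC)c(OC)c(OC)c3)C(=O)CC2O[SiH2]C(C)(C)C)cc1OC` is made from the same atoms as compound 2, joined differently: 3,4-dimethoxyphenyl in place of 2,5-dimethoxyphenyl on a double-bonded ring carbon. Among the measured compounds shown here, one measured step bears on this change: an at least 10-fold lower number from compound 1 to compound 2 (1.02 log units; beyond the scatter). That step was large and beyond the scatter, and it brought in the very group that now leaves. For the measured compounds named here, compound 3 differs from the others in more than one place, so it offers no clean step.

With the 2,5-dimethoxyphenyl group gone, part of the gain in an at least 10-fold lower number from compound 1 to compound 2 (1.02 log units; beyond the scatter) may well be lost, so a higher number, meaning weaker inhibition, is expected. The expected change is a 3.7-fold higher number from compound 2 to compound 4 (0.57 log units; beyond the scatter). For compound 4 the estimated value is 35 ug/mL, with an expected range of 10 ug/mL to 100 ug/mL.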

Compound 4, half-maximal inhibitory concentration: > 100 ug/mL
Compound 4 ended at the assay's limit; the forecaster's own chance of this, stated with the estimate: 35%; middle value at least 2.8-fold (0.45 log units) from the limit.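

In this assay, where the methoxy groups sit matters as well as whether they are present: with the same atoms joined differently, 3,4-dimethoxyphenyl in place of 2,5-dimethoxyphenyl gives an at least 10-fold higher number from compound 2 to compound 4 (1.02 log units; beyond the scatter). A second methoxy group alone therefore does not account for the measurable cytotoxicity of compound 2, since compound 4 also carries two methoxy groups on this phenyl. The step from compound 1 to compound 4 cannot be read, because both values are limits: the limit of > 100 ug/mL in this assay, at which 3 of the 4 values shown sit.

On these data alone, how far compound 4 lies beyond its limit remains unknown, so the full size of the step is open. Also open, as far as these compounds go, is whether an amine or a fluorine in place of either methoxy group of the 2,5-dimethoxyphenyl group would keep a measurable number.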